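From 4-chlorophenyl to 1H-indol-6-yl on the shared core

The source may report more compounds than this note shows. Statements on the series, on what has been measured and on what is new or still open speak of the compounds shown alone.

In a functional assay on HCT-116 cells (Homo sapiens) for inhibition, read by CCK-8 assay, with a stated time of 48 h (on this read-out lower numbers stand for stronger inhibition and higher numbers for weaker inhibition), compound 1 (`COc1cc(-c2cc3nccc(-c4c[nH]c5ccccc45)n3n2)cc(OC)c1OC`) reads > 10000 nM as a limit, not a number. Among the compounds with values here, compound 2 (`COc1cc(-c2ccnc3cc(-c4ccc(Cl)cc4)nn23)cc(OC)c1OC`) gives 3340 nM and so holds the only actual number so far. Compound 3 (`COc1cc(-c2ccnc3cc(-c4ccc5cc[nH]c5c4)nn23)cc(OC)c1OC`) carries 1H-indol-6-yl in place of 4-chlorophenyl on an aromatic carbon of the same core. Within the data shown here, no measured step between compounds differing in one place is available to size this change. In this assay a large move toward stronger inhibition is expected (a 22-fold lower number from compound 2 to compound 3 (1.35 log units; beyond the scatter)) on judgement alone. The expected value for compound 3 is 150 nM within a range of 15 nM to 2500 nM as estimated.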

Compound 3, half-maximal inhibitory concentration: 187 nM
Compound 3: middle estimate off by 1.2-fold (0.10 log units), on the low side; low and high end bracket the measured number.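

This position, on an aromatic carbon next to the ring nitrogen, responds strongly to the group it carries in this assay: 1H-indol-6-yl in place of 4-chlorophenyl gives an 18-fold lower number from compound 2 to compound 3 (1.25 log units; beyond the scatter). Within the data shown here, this is the first sized step, and it lies beyond the scatter. A single pair cannot separate the added five-membered ring, the hydrogen-bond donor and the loss of chlorine.

As far as these compounds go, whether an amine or a carboxylic acid at this position would retain the stronger inhibition remains open. Compound 1 reads only as a limit, so no step to it can be read: the limit of > 10000 nM in this assay, at which 1 of the 3 values shown sits.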